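Furan substituent swap on the aminothienopyrimidine series

This account rests on a few compounds, and the source may have more. Where it says the series, first, only, none or still open, it means among the compounds named here.

Two compounds in this series carry numbers. Among the measured compounds shown here, compound 1 `Cc1ccc(-c2nc(N)c3cc(-c4ccccc4)sc3n2)o1` and compound 2 `CCc1ccc(-c2nc(N)c3cc(Cc4ccccc4)sc3n2)o1` share the core but differ in two places at once, so no single step between them can be counted; the values are simply set side by side. In a functional assay on CHO-K1 cells for antagonist activity at adenosine receptor A1 (Homo sapiens), read by a beta-galactosidase reporter and cAMP accumulation, with stated times of 15 min and 6 h (a lower number here means a stronger inhibitor, a higher number a weaker inhibitor), compound 1 gives 520 nM. In this assay compound 2 gives 223 nM, the lower of the two numbers, and the gap between compound 2 and compound 1 is beyond the scatter.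

Compound 3 `N#Cc1ccc(-c2nc(N)c3cc(Cc4ccccc4)sc3n2)o1` has not yet been measured. It follows from compound 2 by one change, (cyano in place of ethyl on an aromatic carbon), which reads as 5-ethylfuran-2-yl going to 5-cyanofuran-2-yl. Nothing in the measured pair speaks to this substituent on the furan, so the direction is open. The expectation is a small step, a 1.4-fold higher number from compound 2 to compound 3 (0.16 log units; within the scatter), close to the edge of the scatter rather than clearly beyond it. For compound 3 the estimated value in this assay is 320 nM, within a range from 110 nM to 950 nM.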

Compound 3, inhibition constant: 3160 nM
Compound 3: middle estimate off by 9.9-fold (0.99 log units), on the low side; the measured number lies above the stated range.
By their numbers in this assay, from the lowest: compound 2; then compound 1; then compound 3.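

Among the compounds shown here, the only single change that can be read sits on the furan: 5-ethylfuran-2-yl going to 5-cyanofuran-2-yl gives a 14-fold higher number from compound 2 to compound 3 (1.15 log units; beyond the scatter) in this assay, a large step. This carbon, next to the ring oxygen, therefore does not tolerate every small group equally, even though ethyl and cyano each count 2 heavy atoms; what differs by count is that the cyano brings a triple bond and a hydrogen-bond acceptor, and compound 3 is the weaker inhibitor of this pair at 3160 nM against the value of compound 2 at 223 nM in the same assay. Nothing available explains the size of this step, and it is a single pair on one core, so it sets no rule for the series.

From the compounds shown here alone, with only ethyl and cyano compared on the core of compound 2, it remains open whether the weakening follows the cyano specifically or whether ethyl is the unusually favourable partner. A propyl chain, a methoxy group, a chlorine atom or a primary amide at the same furan carbon on that core would show how the number moves across a wider range of groups.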